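The source may report more compounds than this note shows. Statements on the series, on what has been measured and on what is new or still open speak of the compounds shown alone.

Of the compounds shown here, two built on a shared core have been measured so far in a functional assay on HL-60 cells (Homo sapiens) for cytotoxicity, read by WST assay, with a stated time of 48 h; on this read-out higher numbers stand for an effect only at larger amounts of compound and lower numbers for an effect already at smaller amounts. Compound 1 (`COCOc1cccc(C[C@H]2C(=O)OC[C@@H]2Cc2ccccc2)c1`) gives 80000 nM and compound 2 (`O=C1OC[C@H](Cc2ccccc2)[C@H]1Cc1cccc(F)c1`) gives 75000 nM, so compound 2 stands level with compound 1 on these numbers. Repeated measurements of this kind always scatter somewhat, and the two values cannot be told apart.

The next compound, compound 3 (`O=C1OC[C@H](Cc2ccccc2)[C@H]1Cc1ccc(F)c(F)c1`), keeps everything in compound 2 except for one spot on the fluorinated ring: fluoro in place of hydrogen on an aromatic carbon. In words, a fluoro group takes the place of a hydrogen on an aromatic carbon, ortho to the fluoro group already there and para to a large group.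

Among the measured compounds shown here, only one measured step bears on this, namely a 1.1-fold lower number from compound 1 to compound 2 (0.03 log units; within the scatter). That step also changed a group on an aromatic carbon and left a fluoro group in its place, yet the number hardly moved. It was a swap of one group for another rather than an added fluoro group, so it is only a weak guide. No shift beyond the scatter is therefore expected in this assay, in either direction.

The estimate amounts to a 1.3-fold lower number from compound 2 to compound 3 (0.10 log units; within the scatter), which is expected to be no real change. For compound 3 the expected value is 60000 nM, with an estimated range from 25000 nM to 120000 nM.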

Compound 3, half-maximal effective concentration: 50000 nM
Estimate against measurement, compound 3: 1.2-fold (0.08 log units) above, within the range that was stated.
By their numbers in this assay, from the lowest: compounds 3, 2 and 1 (each within the scatter of the next).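

Putting a fluoro group in place of hydrogen on this aromatic carbon, ortho to the fluoro group already there and para to a large group, gives a 1.5-fold lower number from compound 2 to compound 3 (0.18 log units; within the scatter) in this assay, so a second fluoro group here leaves the number inside the usual scatter. The earlier step swapped one group for another on a ring carbon that already carried a substituent, whereas this step fills a carbon that held only hydrogen, and that small addition does not separate compound 3 from compound 2. Nothing measured on these compounds offers an explanation for this result.

On these data alone, whether a different group on this same carbon, such as an amine, a carboxylic acid or a longer chain, would shift the number beyond the scatter remains open. Also open is whether changes on the other aromatic ring or in the shared core would matter more than the fluoro groups have so far, since every step shown here concerns a single ring.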